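The source may hold more compounds than are shown below. What is called first, only, known or untested is meant among the compounds shown, and "the series" means these compounds.

In a functional assay on B16-F0 cells (Mus musculus) for inhibition, read by CCK-8 assay, with a stated time of 48 h (on this read-out higher numbers stand for weaker inhibition and lower numbers for stronger inhibition), three compounds sharing one core have been measured. Compound 1 `COc1cc(-c2ccnc3cc(-c4ccc(F)cc4)nn23)cc(OC)c1OC`, with a 4-fluorophenyl group, gives 4540 nM. Compound 2 `COc1cc(-c2ccnc3cc(-c4cccc(C#N)c4)nn23)cc(OC)c1OC`, with a 3-cyanophenyl group, gives > 10000 nM, which is a limit of the assay and not a number. Compound 3 `COc1cc(-c2ccnc3cc(-c4ccc(C(F)(F)F)cc4)nn23)cc(OC)c1OC`, with a 4-(trifluoromethyl)phenyl group, gives 1770 nM, the lower of the two actual numbers. It stands apart from its nearest neighbour, as a 2.6-fold lower number from compound 1 to compound 3 (0.41 log units; beyond the scatter) shows.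

Compound 4 `COc1cc(-c2ccnc3cc(-c4ccc(C(C)=O)cc4)nn23)cc(OC)c1OC` has not yet been measured. It differs from compound 3 by acetyl in place of trifluoromethyl on an aromatic carbon. Within the data shown here, two measured steps bear on this change. With trifluoromethyl in place of fluoro, the series shows a 2.6-fold lower number from compound 1 to compound 3 (0.41 log units; beyond the scatter), and with 4-(trifluoromethyl)phenyl in place of 3-cyanophenyl it shows an at least 5.6-fold lower number from compound 2 to compound 3 (0.75 log units; beyond the scatter). Among these three compounds, only compound 3 carries trifluoromethyl, and it holds the lowest number. The other two groups both sit higher, and an at least 2.2-fold higher number from compound 1 to compound 2 (0.34 log units; beyond the scatter) shows how far that can go. Losing trifluoromethyl is therefore expected to give back about as much as the step to compound 1, a modest rise. The expected change is a 2.3-fold higher number from compound 3 to compound 4 (0.35 log units; beyond the scatter). For compound 4 the estimated value is 4000 nM, with an expected range from 1500 nM to 10000 nM.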

Compound 4, half-maximal inhibitory concentration: 3930 nM
Compound 4: the middle estimate sits 1.0-fold (0.01 log units) above what was measured; measured number inside the range.
By their numbers in this assay, from the lowest: compound 3; then compounds 4 and 1 (each within the scatter of the next). At a limit, above all of these: compound 2.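

At this position, on an aromatic carbon para to a large group, this assay shows a 2.2-fold higher number from compound 3 to compound 4 (0.35 log units; beyond the scatter), while a 1.2-fold lower number from compound 1 to compound 4 (0.06 log units; within the scatter), so acetyl and fluoro cannot be told apart here and trifluoromethyl alone stays at the lowest number among the four compounds. Among these compounds, the earlier compounds could not show this, as they offered only one group at this place other than trifluoromethyl, and the new result gives a second group that reaches the same level as fluoro rather than that of compound 3. The step to the 3-cyanophenyl compound adds a further contrast, an at least 2.5-fold lower number from compound 2 to compound 4 (0.40 log units; beyond the scatter), but it is only a bound, as compound 2 stands at a limit of the assay and not at a number: the limit of > 10000 nM in this assay, at which 1 of the 4 values shown sits.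

The compounds shown leave open whether any group at this place falls below compound 3, for example trifluoromethoxy, or how an amine or a carboxylic acid would fare there. They also leave open whether a nitrile at the place held by acetyl would sit with acetyl and fluoro, as the only nitrile shown comes as 3-cyanophenyl.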